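This account rests on a few compounds, and the source may have more. Where it says the series, first, only, none or still open, it means among the compounds named here.

Compound 1 `COc1ccc(CNc2nc3cc(N)cc(N)c3nc2-c2ccccc2)cc1OC` stands highest of the two numbers in a functional assay on PC-3 cells (Homo sapiens) for inhibition, read by sulforhodamine B assay, with a stated time of 48 h (on this read-out lower numbers stand for stronger inhibition of growth and higher numbers for weaker inhibition of growth), where compound 1 gives 8320 nM. Its nearest neighbour, compound 2 `COc1cc(CNc2nc3cc(N)cc(N)c3nc2-c2ccccc2)cc(OC)c1OC`, gives 2190 nM in this assay, and the step of a 3.8-fold lower number from compound 1 to compound 2 (0.58 log units; beyond the scatter) came from methoxy in place of hydrogen on an aromatic carbon. Compound 3 `COc1ccc(CNc2nc3cc(N)cc(N)c3nc2-c2ccccc2)cc1` differs from compound 1 by hydrogen in place of methoxy on an aromatic carbon. For the measured compounds named here, the only step bearing on this change runs the other way, and it was modest, so compound 3 is expected to show a modest rise, a 1.8-fold higher number from compound 1 to compound 3 (0.26 log units; within the scatter), toward weaker inhibition of growth. Compound 3 is therefore estimated at 15000 nM in this assay, within 5000 nM to 40000 nM.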

Compound 3, concentration for 50% growth inhibition: 10200 nM
Beside the measured number, compound 3's estimate is 1.5-fold (0.17 log units) above it, and the stated range covers the measured number.
By their numbers in this assay, from the lowest: compound 2; then compounds 1 and 3 (each within the scatter of the next).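

Going from 3,4-dimethoxyphenyl to 4-methoxyphenyl gives a 1.2-fold higher number from compound 1 to compound 3 (0.09 log units; within the scatter) in this assay, so this methoxy, ortho to a methoxy group, can give way to hydrogen without a change beyond the scatter. For the compounds shown here, the earlier compounds showed only the step of a 3.8-fold lower number from compound 1 to compound 2 (0.58 log units; beyond the scatter), which is beyond the scatter and involves a gain of methoxy, so they did not show how the loss of this methoxy would read. On these data alone, what a hydroxyl, an amine or a longer chain such as ethoxy would give on this aromatic carbon stays open. Nothing measured here offers an explanation for this result.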